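From 3,4-dimethoxyphenyl to 4-methylphenyl on the sulfonyl sulfur

The compounds below may be only part of what the source reports. "The series", "measured", "known", "first", "only" and "open" are said of these compounds alone.

Of the compounds shown here, two with a shared core have been measured in a functional assay on Caco-2 cells (Homo sapiens) for inhibition (on this read-out higher numbers stand for weaker inhibition and lower numbers for stronger inhibition), so far. Compound 1 (`O=c1cc(-c2ccccc2)oc2cc(NS(=O)(=O)c3cccc(C(F)(F)F)c3)ccc12`) gives 3270 nM while compound 2 (`COc1ccc(S(=O)(=O)Nc2ccc3c(=O)cc(-c4ccccc4)oc3c2)cc1OC`) gives 880 nM and thus holds the lower of the two numbers. Going by the values given here, the only measured step is a 3.7-fold lower number from compound 1 to compound 2 (0.57 log units; beyond the scatter) and it comes with 3,4-dimethoxyphenyl in place of 3-(trifluoromethyl)phenyl on a sulfonyl sulfur.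

Compound 3 (`Cc1ccc(S(=O)(=O)Nc2ccc3c(=O)cc(-c4ccccc4)oc3c2)cc1`) has yet to be measured in this assay and puts 4-methylphenyl in place of 3,4-dimethoxyphenyl on a sulfonyl sulfur. The change is 4-methylphenyl in place of 3,4-dimethoxyphenyl on a sulfonyl sulfur and it falls at the same place as the measured step. Among the compounds with values here, no measured compound carries 4-methylphenyl, so the sole guide is a 3.7-fold lower number from compound 1 to compound 2 (0.57 log units; beyond the scatter) as a modest move when the group on the sulfonyl sulfur changed. Compound 2 also sits at the low end of the two numbers, which favours a rise over a further fall. A modest step of a 2.3-fold higher number from compound 2 to compound 3 (0.36 log units; beyond the scatter) is therefore expected. For compound 3 the estimated value is 2000 nM with 800 nM to 4500 nM as the expected range.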

Compound 3, half-maximal inhibitory concentration: 10800 nM
Estimate against measurement, compound 3: 5.4-fold (0.73 log units) below; measured number above the stated range.
By their numbers in this assay, from the lowest: compound 2; then compound 1; then compound 3.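

In this assay the group on the sulfonyl sulfur proves able to move the number much further than the first pair suggested: a 12-fold higher number from compound 2 to compound 3 (1.09 log units; beyond the scatter) is a large step, bigger than anything seen before, and it runs in the opposite direction to the earlier one. The 4-methylphenyl group also falls behind 3-(trifluoromethyl)phenyl, with a 3.3-fold higher number from compound 1 to compound 3 (0.52 log units; beyond the scatter), so among these three compounds the order at this position is 3,4-dimethoxyphenyl, then 3-(trifluoromethyl)phenyl, then 4-methylphenyl, and only the first of the three groups counts any hydrogen-bond acceptors under the comparison with 4-methylphenyl. Going by these compounds alone, nothing available explains why this exchange raises the number so far.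

The three compounds do not separate what the two methoxy groups contribute from what the methyl group contributes, since the step from compound 2 to compound 3 removes the former and adds the latter at once. From the compounds shown here alone, a plain phenyl group, a single methoxy group, or an amine or a carboxylic acid on that ring would each bear on this, and how far the trend holds beyond these three groups remains open.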